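Pyrrole ester nucleosides: step from compound 2 to compound 3

The compounds below may be only part of what the source reports. "The series", "measured", "known", "first", "only" and "open" are said of these compounds alone.

Compound 1 `Nc1ncnc2c1ncn2[C@@H]1O[C@H](COC(=O)c2ccc[nH]2)[C@@H](O)[C@H]1O` and compound 2 `O=C(OC[C@H]1O[C@@H](n2cnc3c(=O)[nH]cnc32)[C@H](O)[C@@H]1O)c1ccc[nH]1` share the same core and differ only in the heteroaromatic part. In an assay for inhibition of MAP kinase-activated protein kinase 3 (Homo sapiens), read by Z'-LYTE, with a stated time of 1 h, tested at 10 uM (a higher number here means more inhibition at the concentration tested (going by the name of the read-out), a lower number less inhibition), compound 1 gives 98%, and compound 2 gives 83%. Among the measured compounds shown here, compound 2 thus stands lowest of the two numbers measured so far; the nearest number, that of compound 1, lies higher by a gap beyond the usual scatter.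

Compound 3 `Nc1nc2c(ncn2[C@@H]2O[C@H](COC(=O)c3ccc[nH]3)[C@@H](O)[C@H]2O)c(=O)[nH]1` is the next member and has not yet been measured in this assay. Against compound 2 the change is amino in place of hydrogen on an aromatic carbon. For the measured compounds named here, no measured pair isolates this change, so its size is open. Going by the values given here, the only hint is that compound 1, which bears an amino group, returns the higher of the two known numbers with 98%, while compound 2 lacks one, but that comparison does not isolate the present change. The estimated step is a number 5 percentage points higher from compound 2 to compound 3 (within the scatter), upward and of modest size, possibly not beyond the scatter. Compound 3 is therefore expected to give about 88% in this assay, within a range from 70% to 99%.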

Compound 3, a percentage reported as inhibition, at one concentration (the size of the read-out at that concentration, not a potency): 101%
For compound 3 the middle estimate is 13 percentage points below the measured one; the whole stated range lies below it.
By their numbers in this assay, from the lowest: compound 2; then compounds 1 and 3 (each within the scatter of the next).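

Among the compounds shown here, with a number 18 percentage points higher from compound 2 to compound 3 (beyond the scatter) in this assay, this pair is the first to isolate amino in place of hydrogen on an aromatic carbon, here between two ring nitrogen atoms of the six-membered aromatic ring. The pyrrole ester and the sugar part stay the same across the pair, so the step belongs to this one change and shows that this carbon accepts an amino group without loss of the read-out; compound 3 gives 101% at the one concentration tested, which is a size of inhibition and not a potency. Nothing at hand bears on why the step arises.

The compounds shown leave open how other groups would behave on the same carbon, such as methylamino, dimethylamino, methyl or chlorine, and so whether the step is particular to amino or comes with any group at this place. They also leave open whether the step would carry over if the pyrrole ester gave way to another ester, such as a benzoate, or to an amide.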